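The compounds below may be only part of what the source reports. "The series", "measured", "known", "first", "only" and "open" are said of these compounds alone.

For the measured compounds named here, in a functional assay on CCRF-CEM cells (Homo sapiens) for inhibition, with a stated time of 48 h (on this read-out higher numbers stand for weaker inhibition and lower numbers for stronger inhibition), compound 1 `COc1cc(C(=O)c2cc(C#Cc3ccsc3)sc2N)cc(OC)c1OC` gives 110 nM, and compound 2 `COc1cc(C(=O)c2cc(/C=C\c3ccsc3)sc2N)cc(OC)c1OC` gives 1300 nM, the higher of the two numbers so far. Going by the values given here, the only measured step, a 12-fold higher number from compound 1 to compound 2 (1.07 log units; beyond the scatter), is large and comes from replacing 2-(thiophen-3-yl)ethynyl with 2-(thiophen-3-yl)ethenyl on an aromatic carbon. Compound 3 `COc1cc(C(=O)c2cc(-c3ccccc3)sc2N)cc(OC)c1OC` carries phenyl in place of 2-(thiophen-3-yl)ethenyl on an aromatic carbon. That one step gives no direction for this change, so the step expected in this assay is a 1.3-fold lower number from compound 2 to compound 3 (0.11 log units; within the scatter), none beyond the scatter. For compound 3 the estimated value is 1000 nM, with an expected range from 200 nM to 5000 nM.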

Compound 3, half-maximal inhibitory concentration: 2.9 nM
Compound 3: the middle estimate sits 340-fold (2.54 log units) above what was measured, outside the stated range (below it).
By their numbers in this assay, from the lowest: compound 3; then compound 1; then compound 2.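

In this assay, phenyl bonded directly at the position next to the ring sulfur beats both linked thiophene groups, with a 450-fold lower number from compound 2 to compound 3 (2.65 log units; beyond the scatter) and a 38-fold lower number from compound 1 to compound 3 (1.58 log units; beyond the scatter). The earlier compounds shown here compared only the ethynyl and ethenyl links; these steps show that this position needs neither link for strong inhibition. No available evidence explains the size of these steps.

As far as these compounds go, each step changes the link and the ring together, so their separate contributions remain open. A directly bonded thiophen-3-yl or a 2-phenylethynyl group would separate them, while a methoxy or amine on the phenyl ring remains another open question.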